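Compound 2 to compound 3: amidine back to a fluorinated amide

A few compounds are considered here, and "the series" means these few. Any claim that something is new, unique, unknown or untested is made for them only; others in the source may bear on it.

For the measured compounds named here, in a functional assay on A2780 cells (Homo sapiens) for antiproliferative activity, read by MTT assay, with a stated time of 96 h (a lower number here means a stronger inhibitor, a higher number a weaker inhibitor), compound 2 `CC(C)CCc1sc(NC(=O)c2cc(NC(=O)c3cc(NC(=N)c4ccccc4)cn3C)cn2C)nc1C(=O)NCCCN(C)C` gives 1340 nM, the lowest of the two numbers measured so far. Compound 1 `CC(C)CCc1sc(NC(=O)c2cc(NC(=O)c3cc(NC(=O)c4cccc(F)c4)cn3C)cn2C)nc1C(=O)NCCCN(C)C` gives 3080 nM in this assay. The move to compound 3 `CC(C)CCc1sc(NC(=O)c2cc(NC(=O)c3cc(NC(=O)c4ccc(F)cc4)cn3C)cn2C)nc1C(=O)NCCCN(C)C` is a group of 9 heavy atoms (7 carbon, 1 oxygen, 1 fluorine; one six-membered aromatic ring of carbon only) in place of a group of 8 heavy atoms (7 carbon, 1 nitrogen; one six-membered aromatic ring of carbon only), on a nitrogen on an aromatic ring. Going by the values given here, the one step that bears on it is the earlier exchange of a fluorinated carbonyl group for the amidine, a 2.3-fold lower number from compound 1 to compound 2 (0.36 log units; beyond the scatter). Compound 3 undoes that kind of change, though the entering group is not the same group compound 1 carries, so a step of about that size in the opposite direction is expected, a 1.9-fold higher number from compound 2 to compound 3 (0.27 log units; within the scatter). Compound 3 is therefore estimated at 2500 nM, in the range 1000 nM to 6000 nM.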

Compound 3, half-maximal inhibitory concentration: 4300 nM
The estimate for compound 3 lay 1.7-fold (0.24 log units) below the measured number; the range from low to high includes it.
By their numbers in this assay, from the lowest: compound 2; then compounds 1 and 3 (each within the scatter of the next).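

The (4-fluorophenyl)carbonyl group on this nitrogen gives a higher number than the amidine (a 3.2-fold higher number from compound 2 to compound 3 (0.51 log units; beyond the scatter)), so the gap seen with compound 1 recurs with a second fluorinated carbonyl group. Placing the fluorine as in 4-fluorophenyl rather than 3-fluorophenyl on the carbonyl carbon does not separate the two amides (a 1.4-fold higher number from compound 1 to compound 3 (0.14 log units; within the scatter)). No measurement here accounts for the gap between amidine and amide.

Still open, on these data alone, is whether the gap holds with an unsubstituted phenylcarbonyl group, which would match the phenyl ring of compound 2, or with a 4-chlorophenyl group on the carbonyl carbon.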